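A few compounds are considered here, and "the series" means these few. Any claim that something is new, unique, unknown or untested is made for them only; others in the source may bear on it.

Going by the values given here, in a physicochemical assay for lipophilicity, using the shake flask method, in phosphate buffer, measured as octanol-water partition, with a stated time of 1 h, at pH 7.4 (on this read-out lower numbers stand for lower lipophilicity and higher numbers for higher lipophilicity), compound 1 `CCNC(=O)Nc1cc(Cl)c(-c2cncc(C(=O)O)c2)cn1` gives -1.1, the lower of the two numbers so far, and compound 2 `CCNC(=O)Nc1cc(-c2nc(C(F)(F)F)cs2)c(-c2cncc(C(N)=O)c2)cn1` gives 2. The gap between these two values lies beyond the scatter. Compound 3 `CCNC(=O)Nc1cc(-c2ccncc2)c(-c2cncc(C(=O)O)c2)cn1` has pyridin-4-yl in place of chloro on an aromatic carbon. Among the compounds with values here, no measured pair shows a single change of this kind, so the expectation is loosely founded. No step beyond the scatter is expected, and any shift is expected to be slightly upward: the estimated step runs a number 0.20 log units higher from compound 1 to compound 3 (within the scatter). For compound 3 the estimated value is -0.9, with a range of -1.6 to -0.2.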

Compound 3, distribution coefficient: -0.82
The estimate for compound 3 lay 0.08 log units below the measured number; the measured number falls inside the stated range.
By their numbers in this assay, from the lowest: compounds 1 and 3 (each within the scatter of the next); then compound 2.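

In this assay, the place opposite the ring nitrogen now has its first single-change pair: pyridin-4-yl in place of chloro gives a number 0.28 log units higher from compound 1 to compound 3 (within the scatter) on the core of compound 1. With the carboxylic acid kept, exchanging a single chlorine for a six-membered aromatic ring with 1 hetero atom leaves the read-out within the scatter, in this one pair. No supporting measurement bears on why the two read so closely.

Going by these compounds, whether a phenyl ring or an amine at this place would also stay within the scatter remains open. The same holds for pyridin-4-yl with a methyl ester in place of the carboxylic acid.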